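Cyano for methyl on the aryl ring of compound 3

The source may report more compounds than this note shows. Statements on the series, on what has been measured and on what is new or still open speak of the compounds shown alone.

Measured in a functional assay on NCI-H460 cells (Homo sapiens) for antiproliferative activity, with a stated time of 72 h; a higher number here means a weaker inhibitor, a lower number a stronger inhibitor:
compound 1 `C=CC[C@@H]1C[C@]2([C@@H](C)Cc3ccc(OC)c(OC)c3)OCOC2=CC1=O`: > 4000 nM
compound 2 `C=CC[C@H]1C[C@]2([C@@H](C)Cc3ccccc3)OCOC2=CC1=O`: 9700 nM
compound 3 `C=CC[C@H]1C[C@]2([C@@H](C)Cc3ccc(OC)c(C)c3)OCOC2=CC1=O`: 630 nM

Compound 1 reaches only the limit of the limit of > 4000 nM in this assay, at which 1 of the 3 values shown sits, and gives no number. Of the two numbers, compound 3 holds the lower one; compound 2 sits far higher, beyond the scatter. Compound 4 `C=CC[C@H]1C[C@]2([C@@H](C)Cc3ccc(OC)c(C#N)c3)OCOC2=CC1=O` differs from compound 3 by cyano in place of methyl on an aromatic carbon. Going by the values given here, no comparable step between measured compounds exists here, so the direction is open. A modest weakening is expected, with a real chance that compound 4 also returns only a limit. The expected step of a 3.2-fold higher number from compound 3 to compound 4 (0.50 log units; beyond the scatter) is the working guess. In this assay compound 4 is estimated at 2000 nM, within 500 nM to 8000 nM.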

Compound 4, half-maximal inhibitory concentration: 340 nM
For compound 4 the middle estimate is 5.9-fold (0.77 log units) above the measured one; measured number outside the range, below it.
By their numbers in this assay, from the lowest: compounds 4 and 3 (each within the scatter of the next); then compound 2.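

In this assay, cyano in place of methyl on an aromatic carbon gives a 1.9-fold lower number from compound 3 to compound 4 (0.27 log units; within the scatter) and so shows that this position, ortho to a methoxy group, takes either group with no difference beyond the scatter. The two compounds read alike even though cyano brings a triple bond and a hydrogen-bond acceptor that methyl lacks. Nothing available accounts for this result.

Open, from the compounds shown here alone, is whether an amine or a carboxylic acid at this position would also stay within the scatter of compound 3. Also open, going by these compounds, is whether the parity between cyano and methyl holds in other cell lines.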